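Methoxy Joins the Pendant Phenyl of Compound 2

This account rests on a few compounds, and the source may have more. Where it says the series, first, only, none or still open, it means among the compounds named here.

Of the compounds shown here, three sharing one core have been measured in an assay on CHO cells for displacement of a labelled ligand from adenosine receptor A3 (Homo sapiens), read by scintillation counting, tested at 10 uM; on this read-out lower numbers stand for less inhibition and higher numbers for more inhibition at the one concentration tested (going by the name of the read-out). Compound 1 `CC(C)(C)Cc1csc(N)c1C(=O)c1cccc(Cl)c1` gives 8%. Compound 2 `CC(C)(C)Cc1c(-c2ccccc2)sc(N)c1C(=O)c1cccc(Cl)c1`, which carries phenyl in place of hydrogen on an aromatic carbon, gives 5% in this assay, and the step of a number 3 percentage points lower from compound 1 to compound 2 (within the scatter) lies within the scatter. Compound 3 `CC(C)(C)Cc1c(-c2ccccc2)sc(N)c1C(=O)c1ccc(Cl)c(Cl)c1` gives 6%, with the step of a number 1 percentage points higher from compound 2 to compound 3 (within the scatter) also within the scatter. On the numbers shown, compound 2 sits together with compound 1 and compound 3, its value within the scatter of both, so no order among the three can be read.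

Compound 4 `COc1ccc(-c2sc(N)c(C(=O)c3cccc(Cl)c3)c2CC(C)(C)C)cc1` differs from compound 2 by methoxy in place of hydrogen on an aromatic carbon, placed on an aromatic carbon of the six-membered aromatic ring of carbon only, para to a large group. For the measured compounds named here, no measured step adds a methoxy group, so none bears on this change directly. What the two measured steps do show, a number 3 percentage points lower from compound 1 to compound 2 (within the scatter) and a number 1 percentage points higher from compound 2 to compound 3 (within the scatter), is that additions at aromatic carbons have so far left the read-out within the scatter. One therefore expects no step beyond the scatter, an expected no change at the digits printed from compound 2 to compound 4 (within the scatter). Compound 4 is estimated at 5%, within a range of 0% to 15%.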

Compound 4, a percentage reported as inhibition, at one concentration (the size of the read-out at that concentration, not a potency): 2%
Beside the measured number, compound 4's estimate is 3 percentage points above it; low and high end bracket the measured number.
By their numbers in this assay, from the lowest: compounds 4, 2, 3 and 1 (each within the scatter of the next).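

For the compounds shown here, compound 4 gives the first reading for an oxygen-bearing group at this position, on an aromatic carbon of the six-membered aromatic ring of carbon only, para to a large group, and in this assay methoxy in place of hydrogen there amounts to a number 3 percentage points lower from compound 2 to compound 4 (within the scatter). Counted from the unsubstituted position of the shared core, the whole change of 4-methoxyphenyl in place of hydrogen amounts to a number 6 percentage points lower from compound 1 to compound 4 (within the scatter), so even the two additions taken together do not leave the scatter, which the single steps measured earlier could not show. No measurement offered here accounts for the result, and none bears on the methoxy group in particular.

Since all four compounds lie within the scatter of one another on a single concentration, the compounds shown leave open whether this position can influence the read-out at all. An amine, a hydroxyl or a carboxylic acid in place of the methoxy group, or a longer chain such as ethoxy or butoxy, could test whether any group at this place gives a step beyond the scatter.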